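The source may report more compounds than this note shows. Statements on the series, on what has been measured and on what is new or still open speak of the compounds shown alone.

Working notes on the series. Among the compounds with values here, compound 1 `CC/C(=C(/c1ccc(/C=C/C(=O)O)cc1)c1cc2ccccc2[nH]1)c1ccccc1C` is the reference point here: in a functional assay on MCF7 cells (Homo sapiens) for inhibition (a higher number here means a weaker inhibitor, a lower number a stronger inhibitor), compound 1 gives 33 nM, the highest of the three numbers measured so far. Compound 3 `CC/C(=C(/c1ccc(/C=C/C(=O)O)cc1)c1cc2ccccc2[nH]1)c1ccc(C(F)(F)F)cc1Cl` stands nearest to it, giving 27 nM in this assay, a gap that is within the scatter a 1.2-fold lower number from compound 1 to compound 3 (0.09 log units; within the scatter). Compound 2 `CC/C(=C(/c1ccc(/C=C/C(=O)O)cc1)c1cc2ccccc2[nH]1)c1ccccc1C(F)(F)F` stands furthest away, giving 8 nM in this assay, and the step of a 4.1-fold lower number from compound 1 to compound 2 (0.62 log units; beyond the scatter) is beyond the scatter, as is the step back a 3.4-fold higher number from compound 2 to compound 3 (0.53 log units; beyond the scatter).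

The next compound, compound 4 `CC/C(=C(/c1ccc(/C=C/C(=O)O)cc1)c1cc2ccccc2[nH]1)c1cc(Cl)ccc1Cl`, differs from compound 1 only at the double-bonded chain carbon bound to a double-bonded chain carbon and a saturated chain carbon: 2,5-dichlorophenyl in place of 2-methylphenyl on a double-bonded chain carbon bound to a double-bonded chain carbon and a saturated chain carbon.

Within the data shown here, two measured steps bear on this change. Exchanging the 2-methylphenyl for 2-(trifluoromethyl)phenyl gave a 4.1-fold lower number from compound 1 to compound 2 (0.62 log units; beyond the scatter), a modest gain; exchanging it for 2-chloro-4-(trifluoromethyl)phenyl gave a 1.2-fold lower number from compound 1 to compound 3 (0.09 log units; within the scatter), nothing beyond the scatter. The 2,5-dichlorophenyl entering in compound 4 shares a chlorine with the group in compound 3 rather than the trifluoromethyl of compound 2, so the expectation for compound 4 in this assay is a step of roughly a 1.5-fold lower number from compound 1 to compound 4 (0.18 log units; within the scatter), a small move toward a lower number that may well fall inside the scatter. Compound 4 is therefore estimated at 22 nM in this assay, with a range from 8 nM to 60 nM.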

Compound 4, half-maximal inhibitory concentration: 71 nM
The estimate for compound 4 lay 3.2-fold (0.51 log units) below the measured number; the whole stated range lies below it.
By their numbers in this assay, from the lowest: compound 2; then compounds 3 and 1 (each within the scatter of the next); then compound 4.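

In this assay, within the data shown here, the 2,5-dichlorophenyl is the first group at this double-bonded chain carbon to move the number upward from the 2-methylphenyl reference, with a 2.2-fold higher number from compound 1 to compound 4 (0.33 log units; beyond the scatter) as the step, whereas the two earlier exchanges gave a modest gain or nothing beyond the scatter. Among these compounds, a chlorine on the ring does not by itself fix the outcome here: the 2-chloro-4-(trifluoromethyl)phenyl of compound 3 also carries one, yet the exchange gives a 2.6-fold higher number from compound 3 to compound 4 (0.42 log units; beyond the scatter) as the step, and the comparison with the 2-(trifluoromethyl)phenyl gives an 8.9-fold higher number from compound 2 to compound 4 (0.95 log units; beyond the scatter) as the widest step so far at this carbon, so the choice of ring substituents clearly matters at this position. No data on hand explain why the 2,5-dichlorophenyl sits at the high end of this small set.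

The compounds shown leave open whether the upward step belongs to one chlorine of the pair or needs both, which a single-chlorine group such as 2-chlorophenyl at the same carbon would help to separate. They also leave open how a ring carrying a methoxy group or an amine would behave at this carbon.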